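Fluoro to methyl at the end of the series

The source may report more compounds than this note shows. Statements on the series, on what has been measured and on what is new or still open speak of the compounds shown alone.

In an ADME assay on the whole organism for pharmacokinetics, with Rattus norvegicus as the target (a higher number here means that a larger share of the oral dose reaches the circulation, a lower number that a smaller share of the oral dose reaches the circulation), compound 2 (`O=S(=O)(c1ccc(F)cc1)c1cc(F)c(O)c2ncccc12`) stands highest at 100%, and compound 1 (`O=S(=O)(c1ccc(C(F)(F)F)cc1)c1cc(F)c(O)c2ncccc12`) gives 66%. Compound 3 (`Cc1ccc(S(=O)(=O)c2cc(F)c(O)c3ncccc23)cc1`) differs from compound 2 by methyl in place of fluoro on an aromatic carbon, para to a large group. For the measured compounds named here, the one measured step at this place is a number 34 percentage points higher from compound 1 to compound 2 (beyond the scatter), large and beyond the scatter. Going by the values given here, no methyl compound has been measured. With compound 2 at 100%, a fall smaller than that step is expected in this assay. The estimated step is a number 22 percentage points lower from compound 2 to compound 3 (beyond the scatter). For compound 3 the estimate is 78%, with an expected range of 52% to 100%.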

Compound 3, oral bioavailability: 34%
For compound 3 the middle estimate is 44 percentage points above the measured one; measured number below the stated range.
By their numbers in this assay, from the lowest: compound 3; then compound 1; then compound 2.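

At this place in this assay the series shows a number 66 percentage points lower from compound 2 to compound 3 (beyond the scatter) and a number 32 percentage points lower from compound 1 to compound 3 (beyond the scatter) in the same notes, so methyl stands under both fluorine-bearing groups among these three compounds. Fluoro and methyl each count one heavy atom, with no change in donors, acceptors or net charge, so a large step arises here without any change in those counts. Nothing at hand bears on what lies behind this fall.

Still open, from the compounds shown here alone, is where chloro or methoxy at this place would stand against fluoro and methyl. Also open, going by these compounds, is whether the methyl step holds on another core.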